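Cutting the oxan-4-yl group from compound 3

The source may report more compounds than this note shows. Statements on the series, on what has been measured and on what is new or still open speak of the compounds shown alone.

In a functional assay on FM3A cells (Mus musculus) for cytotoxicity (on this read-out lower numbers stand for an effect already at smaller amounts and higher numbers for an effect only at larger amounts of compound), compound 1 `COOC1(OOC)CCCCCCCCCCC1` gives 1500 nM as its reading, compound 2 `CCOC(C)OOC1(OOC)CCCCCCCCCCC1` gives 12000 nM and compound 3 `COOC1(OOCCCCCCOC2CCOCC2)CCCCCCCCCCC1` gives 7600 nM on the same scale. Compound 3 thus sits within the usual scatter of compound 2, and both lie clearly higher than compound 1.

Compound 4 `COOC1(OOCCCCCCO)CCCCCCCCCCC1` has not been measured yet. It has hydrogen in place of oxan-4-yl on an oxygen on a saturated carbon, a change counted as hydrogen in place of oxan-4-yl on an oxygen on a saturated carbon and leaving a hydroxy group at the chain end.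

Among the measured compounds shown here, only one measured step offers guidance: an 8.0-fold higher number from compound 1 to compound 2 (0.90 log units; beyond the scatter) when 1-ethoxyethyl replaces methyl on an oxygen. That modest step lies beyond the scatter, but it adds a group at a different place, so it bears only loosely here. Read in reverse, it suggests a lower number in this assay when a group leaves. The expected step is a 2.2-fold lower number from compound 3 to compound 4 (0.34 log units; beyond the scatter) on this single comparison. Compound 4 is estimated at 3500 nM with 1200 nM and 10000 nM as the expected ends of the range.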

Compound 4, half-maximal effective concentration: 1600 nM
For compound 4 the middle estimate is 2.2-fold (0.34 log units) above the measured one; measured number inside the range.
By their numbers in this assay, from the lowest: compounds 1 and 4 (each within the scatter of the next); then compounds 3 and 2 (each within the scatter of the next).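

In this assay the group on this oxygen clearly matters, since trading oxan-4-yl for hydrogen gives a 4.8-fold lower number from compound 3 to compound 4 (0.68 log units; beyond the scatter) and leaves a hydroxy group at the chain end. The same chain-ended compound also shows a 7.5-fold lower number from compound 2 to compound 4 (0.88 log units; beyond the scatter) when 6-hydroxyhexyl stands in place of 1-ethoxyethyl, while 5-hydroxypentyl in place of hydrogen gives a 1.1-fold higher number from compound 1 to compound 4 (0.03 log units; within the scatter) and so leaves the reading within the scatter, which means this long chain ending in hydroxy can be carried without a clear change from compound 1. Nothing available here explains why the reading moves with these changes.

Going by these compounds, whether a shorter or longer chain ending in hydroxy would read the same remains open. So does the effect of an amine or a carboxylic acid at the chain end in place of the hydroxy group.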